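Chloro for methoxy on the sulfamoylamino piperidine pyrimidine series

This account rests on a few compounds, and the source may have more. Where it says the series, first, only, none or still open, it means among the compounds named here.

Compound 1 `COc1ccc(-c2cc(N3CCC(CNS(N)(=O)=O)CC3)ncn2)cc1` in a functional assay on HT-29 cells (Homo sapiens) for antiproliferative activity, read by sulforhodamine B assay, with a stated time of 48 h; on this read-out lower numbers stand for stronger inhibition of growth and higher numbers for weaker inhibition of growth: > 100000 nM, a limit of the assay and not a number.
Compound 2 `NS(=O)(=O)NCC1CCN(c2cc(-c3ccc(Cl)cc3)ncn2)CC1` in this assay: 37700 nM.
Compound 3 `COc1ccc(-c2cc(N3CCC(CCNS(N)(=O)=O)CC3)ncn2)cc1` in this assay: 72300 nM.

Two structural differences connect the measured compounds. The first is chloro in place of methoxy on an aromatic carbon, which made the step of an at least 2.6-fold lower number from compound 1 to compound 2 (0.42 log units; beyond the scatter); because compound 1 sits at the limit of > 100000 nM in this assay, at which 1 of the 3 values shown sits, only a floor can be given for this step. The second is (sulfamoylamino)methyl in place of sulfamoylamino on a saturated chain carbon bound to a saturated ring carbon, which made the step of an at least 1.3-fold lower number from compound 1 to compound 3 (0.14 log units; that floor lies within the scatter). Within the data shown here, compound 2 and compound 3 have no step recorded between them; their values stand within the scatter of each other, so no order between them is read here.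

Compound 4 `NS(=O)(=O)NCCC1CCN(c2cc(-c3ccc(Cl)cc3)ncn2)CC1` is not yet measured in this assay. Among the measured compounds shown here, its difference from compound 3 is chloro in place of methoxy on an aromatic carbon, the same change as the one from compound 1 to compound 2, at the same place on the same kind of ring. The expectation for compound 4 therefore rests on that single earlier step: since the step of an at least 2.6-fold lower number from compound 1 to compound 2 (0.42 log units; beyond the scatter) is only a floor, the step from compound 3 is expected to be at least as large, giving an estimated 2.9-fold lower number from compound 3 to compound 4 (0.46 log units; beyond the scatter). Compound 4 is accordingly estimated at 25000 nM in this assay, with a likely range from 8000 nM to 60000 nM; the lower end allows for the true step in compound 1 having been larger than its floor. For the measured compounds named here, this expectation rests on only one pair, compound 1 and compound 2, and so is held loosely.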

Compound 4, concentration for 50% growth inhibition: 30500 nM
Compound 4: middle estimate off by 1.2-fold (0.09 log units), on the low side; the range from low to high includes it.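

Chloro in place of methoxy lowers the number on the core of compound 3 as well, with a 2.4-fold lower number from compound 3 to compound 4 (0.37 log units; beyond the scatter) in this assay, so the 4-methoxyphenyl to 4-chlorophenyl change runs in the same direction on both cores shown, though one of the two steps is only a floor: the same change on two cores in this assay, an at least 2.6-fold lower number (0.42 log units; beyond the scatter) from compound 1 to compound 2 and a 2.4-fold lower number (0.37 log units; beyond the scatter) from compound 3 to compound 4; the limit leaves it open whether they differ. The chain change, (sulfamoylamino)methyl in place of sulfamoylamino, gives a 1.2-fold lower number from compound 2 to compound 4 (0.09 log units; within the scatter) on the chloro side, which sets no order between those two compounds, and the same change on the methoxy side offers only a floor that cannot be told from the scatter: the same change on two cores in this assay, an at least 1.3-fold lower number (0.14 log units; that floor lies within the scatter) from compound 1 to compound 3 and a 1.2-fold lower number (0.09 log units; within the scatter) from compound 2 to compound 4; the limit leaves it open whether they differ. The chloro step therefore rests on two pairs and shows a shared direction, not a shared size and not a rule for the wider series: the limit of > 100000 nM in this assay, at which 1 of the 4 values shown sits.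

As far as these compounds go, whether fluoro, trifluoromethyl or a nitrile at the same place on the aromatic ring would follow chloro stays open, as does the outcome of a hydrogen there in place of any group. Also open, from the compounds shown here alone, is what a longer chain, or an amine or a carboxylic acid in place of the sulfamoylamino end, would do to growth inhibition in this assay.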